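Extending the amine side chain: does tolerance hold?

This account rests on a few compounds, and the source may have more. Where it says the series, first, only, none or still open, it means among the compounds named here.

Compound 1 `Nc1ncc(-c2nc3ccccc3s2)c(N[C@@H]2C[C@H](CO)[C@@H](O)[C@H]2O)n1` and compound 2 `CNc1nc(C)c(-c2nc3ccccc3s2)c(N[C@@H]2C[C@H](CO)[C@@H](O)[C@H]2O)n1` share a core. In an ADME assay on cells (Homo sapiens) for cytotoxicity, read by polymerase chain reaction, with a stated time of 3 days (a higher number here means that more compound is tolerated, a lower number that less compound is tolerated), compound 1 gives only a limit, > 25000 nM. In this assay compound 2 likewise gives only a limit, > 25000 nM. Both values sit at the limit of > 25000 nM in this assay, at which 2 of the 2 values shown sit. Compound 3 `COCCNc1nc(C)c(-c2nc3ccccc3s2)c(N[C@@H]2C[C@H](CO)[C@@H](O)[C@H]2O)n1` differs from compound 2 by methoxymethyl in place of hydrogen on a saturated chain carbon bound to a nitrogen on an aromatic ring. Among the measured compounds shown here, no measured step between compounds that differ in one place is available. The step expected is a number no higher from compound 2 to compound 3 (the limit leaves the size open), none beyond the scatter. Compound 3 is expected to give 25000 nM, from 12500 nM to 50000 nM, most likely reported again only as a limit.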

Compound 3, half-maximal cytotoxic concentration: 21000 nM
Estimate against measurement, compound 3: 1.2-fold (0.08 log units) above, within the range that was stated.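

Among the compounds shown here, compound 3 is the only compound here with a true number rather than a limit, so in this assay the swap of methylamino for (2-methoxyethyl)amino brings the reading within the measurable range (the change is an at least 1.1-fold lower number from compound 2 to compound 3 (0.07 log units; that floor lies within the scatter)). From the compounds shown here alone, that floor does not show a real loss of tolerance, and the true size of the step stays unknown because compound 2 gives only a limit: the limit of > 25000 nM in this assay, at which 2 of the 3 values shown sit.

Still open, going by these compounds, is whether a longer chain, or a terminal amine or carboxylic acid on this chain, would give a clearly different number.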